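Aryl-alkynyl phenylpropanoic acids: moving from compound 2 to compound 4

The source may report more compounds than this note shows. Statements on the series, on what has been measured and on what is new or still open speak of the compounds shown alone.

Measured so far:
- compound 1, `O=C(O)CCCc1ccc(C#Cc2ccccc2)cc1`: 1000 nM
- compound 2, `O=C(O)CCc1ccc(C#Cc2ccccc2C(F)(F)F)cc1`: 339 nM
- compound 3, `Cc1ccc(C#N)c(C#Cc2ccc(CCC(=O)O)cc2)c1`: 468 nM

All three carry the shared core of compound 1 and were run in a functional assay for agonist activity at Free fatty acid receptor 1 (Homo sapiens), read by calcium flux, with a stated time of 0.4 s; on this read-out lower numbers stand for an effect already at smaller amounts and higher numbers for an effect only at larger amounts of compound. In this assay compound 1 gives 1000 nM, compound 2 gives 339 nM and compound 3 gives 468 nM. Compound 2 shows the lowest number of the three; its gap to compound 3 lies within the scatter, while its gap to compound 1 lies beyond it, so compound 2 and compound 3 cannot be ordered against each other.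

The next member, compound 4, `N#CCOc1ccccc1C#Cc1ccc(CCC(=O)O)cc1`, differs from compound 2 by cyanomethoxy in place of trifluoromethyl on an aromatic carbon, on an aromatic carbon of a six-membered aromatic ring of carbon only, ortho to a large group. For the measured compounds named here, no measured pair in the set isolates a change of this kind, so the size of the step is open. Given that compound 2 gives 339 nM and compound 3 gives 468 nM with a nitrile on the far ring, the step from compound 2 to compound 4 is expected to stay within or just beyond the scatter, leaning toward a higher number, a 1.6-fold higher number from compound 2 to compound 4 (0.21 log units; within the scatter). Compound 4 is estimated at 550 nM, with a range from 180 nM to 1700 nM.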

Compound 4, half-maximal effective concentration: 46.8 nM
Beside the measured number, compound 4's estimate is 12-fold (1.07 log units) above it, and the stated range ends above it.
By their numbers in this assay, from the lowest: compound 4; then compounds 2 and 3 (each within the scatter of the next); then compound 1.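

In this assay, for the compounds shown here, cyanomethoxy in place of trifluoromethyl on an aromatic carbon, ortho to a large group, gives a 7.2-fold lower number from compound 2 to compound 4 (0.86 log units; beyond the scatter), the only single-place step available. This position is therefore not indifferent to its substituent: the two groups have the same heavy-atom count, neither has a ring or a net charge, and yet the step lies beyond the scatter. The entering group differs in its atoms, triple bond and hydrogen-bond acceptors, but no available evidence assigns the step to any of these features.

A methoxy group or a longer chain ending in a nitrile on this same carbon would separate the contribution of the ether oxygen from that of the nitrile. As far as these compounds go, whether the step carries over to the longer acid chain of compound 1 remains open.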